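Removing the triple bond from compound 2

The source may hold more compounds than are shown below. What is called first, only, known or untested is meant among the compounds shown, and "the series" means these compounds.

Among the measured compounds shown here, in a functional assay on NCI-H460 cells (Homo sapiens) for antiproliferative activity, with a stated time of 72 h (a lower number here means a stronger inhibitor, a higher number a weaker inhibitor), compound 2 `Nc1ncnn2c([C@@H]3O[C@H](CO)[C@@H](O)[C@H]3O)cc(C#Cc3ccccc3)c12` gives 38500 nM, the higher of the two numbers measured so far, while compound 1 `CCCCC#Cc1cc([C@@H]2O[C@H](CO)[C@@H](O)[C@H]2O)n2ncnc(N)c12` gives 1700 nM. Compound 3 `Nc1ncnn2c([C@@H]3O[C@H](CO)[C@@H](O)[C@H]3O)cc(-c3ccccc3)c12` carries phenyl in place of 2-phenylethynyl on an aromatic carbon. Its phenyl ring stays, but the triple bond goes. For the measured compounds named here, no measured step removes a triple bond, so the evidence is indirect. Going by the values given here, the only measured step, a 23-fold higher number from compound 1 to compound 2 (1.36 log units; beyond the scatter), is large and shows that swapping butyl for phenyl on a triple-bonded carbon can shift the number widely, but it does not fix a direction for this change. With compound 2 already at 38500 nM, a small move toward a lower number is expected, with a wide margin. The expected step is a 1.8-fold lower number from compound 2 to compound 3 (0.24 log units; within the scatter). Compound 3 is estimated at 22000 nM, within a range of 5000 nM to 80000 nM.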

Compound 3, half-maximal inhibitory concentration: > 100000 nM
Compound 3: only a limit was reported (the forecaster's own chance of this, stated with the estimate: 25%); at least 4.5-fold (0.65 log units) between middle value and limit.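

In this assay compound 3 is reported only as a limit, not as a number: the limit of > 100000 nM in this assay, at which 1 of the 3 values shown sits. Taking out the triple bond while keeping the phenyl ring gives an at least 2.5-fold higher number from compound 2 to compound 3 (0.41 log units; beyond the scatter), so at this aromatic carbon the change leads to a weaker inhibitor, which the earlier pair could not show, since both of its compounds kept the triple bond. Replacing hex-1-yn-1-yl by phenyl gives an at least 58-fold higher number from compound 1 to compound 3 (1.76 log units; beyond the scatter), the widest step shown at this position.

As far as these compounds go, how far compound 3 lies past its limit stays open, so the full size of both steps is unknown. Also open, from the compounds shown here alone, is whether a saturated hexyl chain, or a triple-bonded chain ending in an amine, would hold the number of compound 1, and so why the triple bond and the butyl end each count here.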